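The source may hold more compounds than are shown below. What is called first, only, known or untested is meant among the compounds shown, and "the series" means these compounds.

Compound 1 `Cc1cc2nc(-c3ccco3)n(-c3ccc4c(N)nc(N)nc4c3)c2cc1C`: 943 nM
Compound 2 `Cc1cc2nc(-c3ccncc3)n(-c3ccc4c(N)nc(N)nc4c3)c2cc1C`: 437 nM

Both compounds share one core and differ only in the group carried on one aromatic carbon of that core. In an assay on isolated protein for inhibition of Dihydrofolate reductase (Homo sapiens), read by spectrophotometry, using NADPH, with a stated time of 10 min (on this read-out higher numbers stand for weaker inhibition and lower numbers for stronger inhibition), compound 2 gives 437 nM, the lower of the two numbers and therefore the stronger inhibition; compound 1 gives 943 nM. For the measured compounds named here, the only step seen so far is a 2.2-fold lower number from compound 1 to compound 2 (0.33 log units; beyond the scatter), in which pyridin-4-yl took the place of furan-2-yl.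

Compound 3 `Cc1cc2nc(C3CCCO3)n(-c3ccc4c(N)nc(N)nc4c3)c2cc1C` is not yet measured. It differs from compound 2 by oxolan-2-yl in place of pyridin-4-yl on an aromatic carbon. Going by the values given here, the one measured step that bears on this change is a 2.2-fold lower number from compound 1 to compound 2 (0.33 log units; beyond the scatter), a modest gain on moving away from a five-membered ring with one oxygen to pyridin-4-yl. Oxolan-2-yl brings back a five-membered ring with one oxygen, now non-aromatic, so the expected move is roughly the reverse of that step: a modest rise in the number, a 2.3-fold higher number from compound 2 to compound 3 (0.36 log units; beyond the scatter), with the lack of any measured non-aromatic group widening the range. Compound 3 is therefore expected to give about 1000 nM, between 400 nM and 2500 nM.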

Compound 3, inhibition constant: 749 nM
For compound 3 the middle estimate is 1.3-fold (0.13 log units) above the measured one; the measured number falls inside the stated range.
By their numbers in this assay, from the lowest: compounds 2, 3 and 1 (each within the scatter of the next, the first and the last beyond it).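

Swapping the six-membered aromatic pyridin-4-yl for the five-membered non-aromatic oxolan-2-yl gives a 1.7-fold higher number from compound 2 to compound 3 (0.23 log units; within the scatter) in this assay, while swapping furan-2-yl for oxolan-2-yl on the same aromatic carbon gives a 1.3-fold lower number from compound 1 to compound 3 (0.10 log units; within the scatter). Until now this position had carried only aromatic rings, and these steps show that in this set a non-aromatic ring cannot be told apart from either of them, leaving the step between the two aromatic groups, compound 1 and compound 2, as the only one beyond the scatter. On these data alone, nothing available explains how these three groups compare, so the reason for this pattern remains unknown.

As far as these compounds go, all three groups are single rings holding one hetero atom, so it remains open whether the position would give similar numbers with a group lacking a ring, such as an amine, a carboxylic acid or a longer alkyl chain. Also open, from the compounds shown here alone, is whether a larger ring system, such as naphthyl, would fit as well as these single rings do.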